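This account rests on a few compounds, and the source may have more. Where it says the series, first, only, none or still open, it means among the compounds named here.

Compound 1 `Cc1ccc(S(=O)(=O)N[C@H]2CC[C@@H](F)[C@@H]2C/C=C\CCCC(=O)O)cc1` and compound 2 `O=C(O)CCC/C=C\C[C@H]1[C@H](F)CC[C@@H]1NS(=O)(=O)c1ccccc1` share one core and differ in a single place on the aromatic ring. In a functional assay on a cell-free system (plasma) for inhibition of thromboxane A2 receptor (Homo sapiens), read by turbidimetry (on this read-out higher numbers stand for weaker inhibition and lower numbers for stronger inhibition), compound 1 gives 260 nM, while compound 2 gives 1100 nM. The step of a 4.2-fold higher number from compound 1 to compound 2 (0.63 log units; beyond the scatter) is therefore a clear loss of inhibition. For the measured compounds named here, of the two numbers so far, compound 2 stands highest, so it is the weaker inhibitor, with compound 1 the nearest and lower number. Compound 3 `O=C(O)CCC/C=C\C[C@H]1[C@H](F)CC[C@@H]1NS(=O)(=O)c1ccccc1[N+](=O)[O-]` has not yet been measured. It differs from compound 2 in one respect: nitro in place of hydrogen on an aromatic carbon. Going by the values given here, only one measured step exists, and it concerns a different change, the loss of a methyl, at a different place on the ring, so it does not tell what this nitro group will do; it shows only that a single change on this ring can move this assay by a modest amount. With no direct guide, compound 3 is expected to come out near 1500 nM, within a range from 400 nM to 6000 nM. That estimate corresponds to an expected step of a 1.4-fold higher number from compound 2 to compound 3 (0.13 log units; within the scatter), which may well lie within the scatter.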

Compound 3, half-maximal inhibitory concentration: 1800 nM
For compound 3 the middle estimate is 1.2-fold (0.08 log units) below the measured one; the range from low to high includes it.
By their numbers in this assay, from the lowest: compound 1; then compounds 2 and 3 (each within the scatter of the next).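

In this assay, a nitro group on the aromatic carbon ortho to a large group leaves the number indistinguishable from that of the unsubstituted phenyl ring (a 1.6-fold higher number from compound 2 to compound 3 (0.21 log units; within the scatter)), so this position tolerates a group of three heavy atoms with no measurable change in inhibition. Replacing 4-methylphenyl with 2-nitrophenyl gives a larger step that is clearly real (a 6.9-fold higher number from compound 1 to compound 3 (0.84 log units; beyond the scatter)), so the nitro group does not recover the inhibition seen with the methyl-bearing ring, and among these three compounds only compound 1, the one carrying the methyl group, stands apart from the others. No measurement here explains why the nitro group makes so little difference at this position.

The compounds shown leave open whether an amine or a carboxylic acid on that same aromatic carbon would also leave the number unchanged, or would shift it beyond the scatter. They also leave open whether a nitro group elsewhere on the ring, or a methyl group on this same carbon, would match the inhibition of compound 1.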